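A few compounds are considered here, and "the series" means these few. Any claim that something is new, unique, unknown or untested is made for them only; others in the source may bear on it.

In a functional assay on MOLT-4F cells (Homo sapiens) for antiproliferative activity (on this read-out higher numbers stand for weaker inhibition of growth and lower numbers for stronger inhibition of growth), compound 1 `COC(=O)CCCCCCCCCCCCCC/C=C1\CC(CO)(COC(=O)C(C)(C)C)OC1=O` reaches only a limit, > 10 ug/mL. Among the compounds with values here, compound 2 `CCCCCCCCC(O)CCCCCC/C=C1\CC(CO)(COC(=O)C(C)(C)C)OC1=O` gives 7.91 ug/mL, the only actual number on this scale so far. Compound 3 `CCCCCOCCCCCCC/C=C1\CC(CO)(COC(=O)C(C)(C)C)OC1=O` departs from compound 2 in one place: (pentyloxy)methyl in place of 1-hydroxynonyl on a saturated chain carbon, six bonds along the chain from a double-bonded chain carbon, with (pentyloxy)methyl in place of 1-hydroxynonyl on a saturated chain carbon, six bonds along the chain from a double-bonded chain carbon. Within the data shown here, no measured pair shows what such a change does in this assay. The expected shift, a 1.3-fold higher number from compound 2 to compound 3 (0.10 log units; within the scatter), leans slightly toward weaker inhibition of growth but stays within the scatter. Compound 3 is estimated at 10 ug/mL, with an expected range of 4.5 ug/mL to 22 ug/mL.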

Compound 3, concentration for 50% growth inhibition: 1.03 ug/mL
The estimate for compound 3 lay 9.7-fold (0.99 log units) above the measured number, outside the stated range (below it).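

In this assay the group at this chain position clearly matters: (pentyloxy)methyl in place of 1-hydroxynonyl gives a 7.7-fold lower number from compound 2 to compound 3 (0.89 log units; beyond the scatter) on this single pair. Pentyloxy in place of 7-(methoxycarbonyl)heptyl gives an at least 9.7-fold lower number from compound 1 to compound 3 (0.98 log units; beyond the scatter) in the same direction, but this step is only a bound, since compound 1 stands at a limit: the limit of > 10 ug/mL in this assay, at which 1 of the 3 values shown sits. The step from compound 2 both removes the hydrogen-bond donor and shortens the group from 10 heavy atoms to 7, and the pair does not separate the two.

Going by these compounds, whether the ether oxygen itself matters stays open, as a plain alkyl chain would show. So does the effect of an amine, a carboxylic acid or a longer alkoxy chain at this position.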